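From nitro to chloro on an aromatic ring

A few compounds are considered here, and "the series" means these few. Any claim that something is new, unique, unknown or untested is made for them only; others in the source may bear on it.

Compound 1 `C=C1CC[C@H]2C(C)(C)CCC[C@]2(C)[C@H]1CCC(C)CC(=O)O`: 168000 nM
Compound 2 `C=C1CC[C@H]2C(C)(C)CCC[C@]2(C)[C@H]1CCC(C)CC(=O)OC`: > 200000 nM (a limit of the assay, not a number)
Compound 3 `CC(CC[C@H]1/C(=C/c2ccc([N+](=O)[O-])cc2)CC[C@H]2C(C)(C)CCC[C@]12C)CC(=O)O`: 194000 nM

These values come from an ADME assay on HUVEC cells (Homo sapiens) for cytotoxicity, read by MTT assay, with a stated time of 72 h; on this read-out lower numbers stand for stronger inhibition and higher numbers for weaker inhibition. Compound 1 gives 168000 nM and compound 3 gives 194000 nM, and these two numbers lie within the scatter of each other. Among the compounds with values here, compound 3 therefore stands level with the only other true number in the set.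

Compound 4 `CC(CC[C@H]1/C(=C/c2ccc(Cl)cc2)CC[C@H]2C(C)(C)CCC[C@]12C)CC(=O)O` differs from compound 3 in one place: chloro in place of nitro on an aromatic carbon. Put simply, it has chloro in place of nitro on an aromatic carbon, para to a large group.

Within the data shown here, no measured step tests this swap directly. Among the measured compounds shown here, the only measured step, an at least 1.1-fold higher number from compound 1 to compound 2 (0.07 log units; that floor lies within the scatter), puts a methyl in place of a hydrogen and leaves the aromatic ring out of play. Compound 1 at 168000 nM and compound 3 at 194000 nM also sit close together, so no step beyond the scatter is expected in this assay, in either direction.

Compound 2 stands at the limit of > 200000 nM in this assay, at which 1 of the 3 values shown sits. A limit instead of a number is therefore possible for compound 4 too.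

The estimated 1.3-fold lower number from compound 3 to compound 4 (0.11 log units; within the scatter) stays within the usual scatter. For compound 4 the expected value is 150000 nM, with an estimated range from 80000 nM to 200000 nM.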

Compound 4, half-maximal inhibitory concentration: > 200000 nM
Compound 4: only a limit was reported (the forecaster's own chance of this, stated with the estimate: 25%); at least 1.3-fold (0.12 log units) between middle value and limit.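

In this assay, the swap of 4-nitrophenyl to 4-chlorophenyl gives an at least 1.0-fold higher number from compound 3 to compound 4 (0.01 log units; that floor lies within the scatter). Compound 4 has only a limit of the assay, not a number: > 200000 nM. Among the other compounds only compound 3 carries an aromatic ring, so this is the first view of a second group on that aromatic carbon, para to a large group: nitro can give way to chloro with no sign of stronger inhibition, although the true size of the step cannot be read, and the set now holds a second compound at this limit: the limit of > 200000 nM in this assay, at which 2 of the 4 values shown sit.

The compounds shown leave open how an amine, a methoxy group or a fluoro on the same aromatic carbon would read, and whether a plain phenyl ring, with hydrogen there, would give a true number or the same limit. Within the data shown here, they also leave open whether the methyl ester of compound 3 or of compound 4 would read as compound 2 does, since that change has been seen only on the core of compound 1.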